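Lengthening the Amide Chain from Methyl to Ethyl

The compounds below may be only part of what the source reports. "The series", "measured", "known", "first", "only" and "open" are said of these compounds alone.

Among the measured compounds shown here, in a functional assay on U-87MG ATCC cells for antiproliferative activity against U-87 MG (Homo sapiens), read by MTT assay, with a stated time of 72 h (a higher number here means a weaker inhibitor, a lower number a stronger inhibitor), compound 1 `CNC(=O)c1cc(Oc2ccc(NC(=O)c3cc4cccnc4n(-c4ccccc4F)c3=O)cc2)ccn1` gives 3360 nM, the lowest of the two numbers known; compound 3 `CNC(=O)c1cc(Oc2ccc(NC(=O)c3cc4cccnc4n(-c4ccc(C(F)(F)F)cc4Cl)c3=O)cc2)ccn1` gives 19800 nM, and compound 2 `CNC(=O)c1cc(Oc2ccc(NC(=O)c3cc4cccnc4n(-c4ccc(Br)cc4F)c3=O)cc2)ccn1` gives "not determined" (no result reported). For the measured compounds named here, the only measured step, a 5.9-fold higher number from compound 1 to compound 3 (0.77 log units; beyond the scatter), alters the ring on the aromatic nitrogen. Compound 4 `CCNC(=O)c1cc(Oc2ccc(NC(=O)c3cc4cccnc4n(-c4ccccc4F)c3=O)cc2)ccn1` changes a different part: methyl in place of hydrogen on a saturated chain carbon bound to an amide-type nitrogen. Going by the values given here, no measured step touches this carbon, so nothing shows how it shifts this assay. The expectation for compound 4 is therefore a step of a 1.0-fold higher number from compound 1 to compound 4 (0.02 log units; within the scatter), within the scatter. Compound 4 is thus estimated at 3500 nM in this assay, with a range from 1400 nM to 9000 nM.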

Compound 4, half-maximal inhibitory concentration: 3250 nM
Beside the measured number, compound 4's estimate is 1.1-fold (0.03 log units) above it; measured number inside the range.
By their numbers in this assay, from the lowest: compounds 4 and 1 (each within the scatter of the next); then compound 3.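

Replacing hydrogen with methyl on this saturated chain carbon, which turns methylcarbamoyl into ethylcarbamoyl, gives in this assay a 1.0-fold lower number from compound 1 to compound 4 (0.01 log units; within the scatter), so the two compounds cannot be told apart. Among the compounds shown here, this is the first reading at this position, and here the ethyl group is accepted as readily as the methyl group. Nothing available explains this result.

Going by these compounds, whether a longer chain such as propyl, or a ring such as cyclopropyl, would be accepted here remains open. So does whether ethyl would read the same in compound 3.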